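Little Movement at the Sulfur-Bound Chain Carbon

A few compounds are considered here, and "the series" means these few. Any claim that something is new, unique, unknown or untested is made for them only; others in the source may bear on it.

Values in a toxicity assay on GES1 cells (Homo sapiens) for inhibition, read by MTT assay, with a stated time of 72 h; a higher number here means a weaker inhibitor, a lower number a stronger inhibitor:
- compound 1 `Cc1cc(N2CC[C@@H](C)[C@@H](N(C)c3ncnc4[nH]ccc34)C2)n2nc(SCc3ccccc3)nc2n1`: 67200 nM
- compound 2 `Cc1cc(N2CC[C@@H](C)[C@@H](N(C)c3ncnc4[nH]ccc34)C2)n2nc(SCc3nc4ccccc4[nH]3)nc2n1`: 40200 nM
- compound 3 `Cc1cc(N2CC[C@@H](C)[C@@H](N(C)c3ncnc4[nH]ccc34)C2)n2nc(SCCc3ccccc3)nc2n1`: 66200 nM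

Compound 3 stands level with both other compounds. The measured steps of a 1.0-fold lower number from compound 1 to compound 3 (0.01 log units; within the scatter) and a 1.6-fold higher number from compound 2 to compound 3 (0.22 log units; within the scatter) lie within the scatter, as does a 1.7-fold lower number from compound 1 to compound 2 (0.22 log units; within the scatter).

Compound 4 `Cc1cc(N2CC[C@@H](C)[C@@H](N(C)c3ncnc4[nH]ccc34)C2)n2nc(SCc3ccc(F)c(Cl)c3)nc2n1` carries 3-chloro-4-fluorophenyl in place of benzyl on a saturated chain carbon bound to a sulfur. Among the measured compounds shown here, no measured compound carries this group, so the evidence is indirect. All three steps bear on it as changes at this same place, and none exceeds the scatter. Accordingly, no shift beyond the scatter is expected in this assay.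

The expected change is a 1.2-fold lower number from compound 3 to compound 4 (0.08 log units; within the scatter).

Compound 4 is estimated at 55000 nM, with an expected range of 25000 nM to 110000 nM.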

Compound 4, half-maximal inhibitory concentration: > 100000 nM
Compound 4 ended at the assay's limit; the forecaster's own chance of this, stated with the estimate: 10%; at least 1.8-fold (0.25 log units) between middle value and limit.
By their numbers in this assay, from the lowest: compounds 2, 3 and 1 (each within the scatter of the next). At a limit, above all of these: compound 4.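

In this assay compound 4 alone reaches the limit of the assay, so its reading is a limit and not a number: the limit of > 100000 nM in this assay, at which 1 of the 4 values shown sits. The place is not wholly silent, since there is an at least 2.4-fold higher number from compound 2 to compound 4 (0.39 log units; beyond the scatter), a step that the earlier changes at this carbon did not produce. The other two steps, an at least 1.5-fold higher number from compound 3 to compound 4 (0.17 log units; that floor lies within the scatter) and an at least 1.4-fold higher number from compound 1 to compound 4 (0.17 log units; that floor lies within the scatter), have floors within the scatter and alone show no separation.

As far as these compounds go, how far compound 4 lies past the limit stays open. So does whether a phenyl carrying only a fluorine, only a chlorine or an amine would behave alike.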